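Phenyl in Place of Trifluoromethyl on a Phenoxypropanoic Acid

The source may report more compounds than this note shows. Statements on the series, on what has been measured and on what is new or still open speak of the compounds shown alone.

Compound 1 `O=C(O)CCc1ccc(OCc2cccc(Br)c2)cc1` carries bromo on its outer aromatic ring, and in a functional assay on 1321-N1 cells for agonist activity at Free fatty acid receptor 1 (Homo sapiens), read by calcium flux (on this read-out lower numbers stand for smaller maximal responses and higher numbers for larger maximal responses), compound 1 gives 99%. Compound 2 `O=C(O)CCc1ccc(OCc2cccc(C(F)(F)F)c2)cc1` has trifluoromethyl in the same place, and in this assay compound 2 gives 103%. Going by the values given here, the only measured step is a number 4 percentage points higher from compound 1 to compound 2 (within the scatter); compound 2 and compound 1 therefore lie within the scatter of one another, and neither can be called the larger on these two numbers.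

Compound 3 `O=C(O)CCc1ccc(OCc2cccc(-c3ccccc3)c2)cc1` is not yet measured. It differs from compound 2 by phenyl in place of trifluoromethyl on an aromatic carbon. Among the compounds with values here, the single step that bears on this position, the exchange of bromo for trifluoromethyl, stayed within the scatter, so a change at the same place is expected to give no step beyond the scatter in this assay either. For compound 3 the expected value in this assay is 100%, within a range of 85% to 115%. This estimate amounts to an expected step of a number 3 percentage points lower from compound 2 to compound 3 (within the scatter).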

Compound 3, largest response reached (reported as efficacy), in percent of the reference or control that the assay uses: 105%
Estimate against measurement, compound 3: 5 percentage points below; low and high end bracket the measured number.
By their numbers in this assay, from the lowest: compounds 1, 2 and 3 (each within the scatter of the next).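

Exchanging trifluoromethyl for phenyl on this aromatic carbon gives in this assay a number 2 percentage points higher from compound 2 to compound 3 (within the scatter) and exchanging bromo for phenyl gives a number 6 percentage points higher from compound 1 to compound 3 (within the scatter) so neither step leaves the scatter. The earlier compounds shown here showed this only for two groups without a ring; compound 3 shows that a six-membered aromatic ring of carbon only can stand at this place with no step beyond the scatter. Bromo, trifluoromethyl and phenyl therefore cannot be told apart by their maximal responses here, and nothing available explains this result.

On these data alone, whether an amine, a carboxylic acid or a longer chain at this place would also stay within the scatter remains open. As far as these compounds go, these numbers describe only the largest response, so how much of each compound is needed to reach it also remains open.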